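Nitro in Place of Methoxy: Expectation for Compound 4

A few compounds are considered here, and "the series" means these few. Any claim that something is new, unique, unknown or untested is made for them only; others in the source may bear on it.

Three measured compounds share one core and differ only in the group on the sulfonamide nitrogen. Compound 1 `CC1(C)C=C(n2ccccc2=O)c2cc(S(N)(=O)=O)ccc2O1` carries hydrogen there, and in a functional assay on the whole organism (aorta) with Rattus norvegicus as the target (on this read-out higher numbers stand for larger maximal responses and lower numbers for smaller maximal responses), compound 1 reaches 77.5%. Compound 2 `CC(C)NS(=O)(=O)c1ccc2c(c1)C(n1ccccc1=O)=CC(C)(C)O2` carries isopropyl, and in this assay compound 2 reaches 76.9%. Compound 3 `COc1ccc(NS(=O)(=O)c2ccc3c(c2)C(n2ccccc2=O)=CC(C)(C)O3)cc1` carries 4-methoxyphenyl, and in this assay compound 3 reaches 77.9%. Compound 3 sits at the top of the three numbers, yet the steps leading to it, a number 0.4 percentage points higher from compound 1 to compound 3 (within the scatter) and a number 1 percentage points higher from compound 2 to compound 3 (within the scatter), both lie within the scatter, as does a number 0.6 percentage points lower from compound 1 to compound 2 (within the scatter).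

Compound 4 `CC1(C)C=C(n2ccccc2=O)c2cc(S(=O)(=O)Nc3ccc([N+](=O)[O-])cc3)ccc2O1` differs from compound 3 by nitro in place of methoxy on an aromatic carbon. Among the compounds with values here, none of the measured steps concerns this exact change; all three alter the group on the sulfonamide nitrogen itself, and within these three compounds every such alteration has left the maximal response in this assay unchanged beyond the scatter. On that basis the move from compound 3 to compound 4 is expected to give no step beyond the scatter, a number 0.1 percentage points higher from compound 3 to compound 4 (within the scatter). Compound 4 is therefore estimated to reach 78% in this assay, with an expected range from 70% to 86%.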

Compound 4, largest response reached (Emax), in percent of the reference or control that the assay uses: 82.2%
Beside the measured number, compound 4's estimate is 4.2 percentage points below it; measured number inside the range.
By their numbers in this assay, from the lowest: compounds 2, 1, 3 and 4 (each within the scatter of the next).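

In this assay, nitro in place of methoxy on an aromatic carbon, para to a large group, gives a number 4.3 percentage points higher from compound 3 to compound 4 (within the scatter), so this first change away from the sulfonamide nitrogen itself also stays within the scatter. The 4-nitrophenyl group behaves the same way when set against the smaller groups on that nitrogen, with a number 4.7 percentage points higher from compound 1 to compound 4 (within the scatter) against hydrogen and a number 5.3 percentage points higher from compound 2 to compound 4 (within the scatter) against isopropyl, so hydrogen, isopropyl, 4-methoxyphenyl and 4-nitrophenyl cannot be told apart in this assay across these four compounds. No available evidence bears on what lies behind these numbers.

The compounds shown leave open whether an amine or a carboxylic acid at this same aromatic carbon would produce a step beyond the scatter, or whether this carbon would simply continue to accept such exchanges. They also leave open whether a longer chain on the sulfonamide nitrogen, or a replacement of the sulfonamide itself, would move the maximal response in this assay beyond the scatter.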